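Removing the pyridyl cap from the amine-linked piperazine

A few compounds are considered here, and "the series" means these few. Any claim that something is new, unique, unknown or untested is made for them only; others in the source may bear on it.

Three compounds share one core. Compound 1 `CCNc1cccnc1N1CCN(C(=O)C2(C)CCc3c(C)c(O)c(C)c(C)c3O2)CC1` gives 12000 nM in a functional assay (brain) for inhibition, with Rattus norvegicus as the target; a higher number here means a weaker inhibitor, a lower number a stronger inhibitor; compound 2 `Cc1c(C)c2c(c(C)c1O)CCC(C)(C(=O)N1CCNCC1)O2` gives 10000 nM in this assay; compound 3 `CCNc1cccnc1N1CCN(CC2(C)CCc3c(C)c(O)c(C)c(C)c3O2)CC1` gives 1000 nM in this assay, the lowest of the three numbers, a gap beyond the scatter to both others. Compound 4 `Cc1c(C)c2c(c(C)c1O)CCC(C)(CN1CCNCC1)O2` has not been measured. It differs from compound 3 by hydrogen in place of 3-(ethylamino)pyridin-2-yl on an amine nitrogen in a ring. The same change was seen on the amide series: a 1.2-fold lower number from compound 1 to compound 2 (0.08 log units; within the scatter), within the scatter. That single step suggests no change beyond the scatter for this step either. For compound 4 the expected number in this assay is 1000 nM (range 400 nM to 3000 nM). The estimated step is therefore no change at the digits printed from compound 3 to compound 4 (within the scatter), expected to stay within the scatter.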

Compound 4, half-maximal inhibitory concentration: 1000 nM
Beside the measured number, compound 4's estimate shows no gap at the digits printed, and the stated range covers the measured number.
By their numbers in this assay, from the lowest: compounds 3 and 4 (each within the scatter of the next); then compounds 2 and 1 (each within the scatter of the next).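

On the core of compound 3, the step in this assay reads no change at the digits printed from compound 3 to compound 4 (within the scatter), so this position tolerates the loss of the 3-(ethylamino)pyridin-2-yl group on the amine-linked core as well. Until now that had been seen only on the amide series, and the outcome now holds on both cores: the same change on two cores in this assay, a 1.2-fold lower number (0.08 log units; within the scatter) from compound 1 to compound 2 and no change at the digits printed (within the scatter) from compound 3 to compound 4, 1.2-fold (0.08 log units) apart, within the scatter of two such steps

The compounds shown carry only hydrogen or 3-(ethylamino)pyridin-2-yl on this ring nitrogen. Going by these compounds, what a methyl, an acetyl or a benzyl group there would give in this assay remains open.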